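Cyano in Place of Ethoxy on the Shared Core

The source may report more compounds than this note shows. Statements on the series, on what has been measured and on what is new or still open speak of the compounds shown alone.

Three compounds share one core and differ only in the group on an aromatic carbon that sits ortho to a methylsulfonyl group. Compound 1 `CCSc1cc(C)c(C(=O)N=C(N)N)cc1S(C)(=O)=O` gives 5.9 nM in a functional assay for inhibition of sodium/hydrogen exchanger (Oryctolagus cuniculus); on this read-out lower numbers stand for stronger inhibition and higher numbers for weaker inhibition. Compound 2 `Cc1cc(Sc2ccccc2)c(S(C)(=O)=O)cc1C(=O)N=C(N)N` gives 14 nM in this assay, and compound 3 `CCOc1cc(C)c(C(=O)N=C(N)N)cc1S(C)(=O)=O` gives 19 nM. Compound 3 thus holds the highest number of the three: against compound 1 the gap is a 3.2-fold higher number from compound 1 to compound 3 (0.51 log units; beyond the scatter), against compound 2 only a 1.4-fold higher number from compound 2 to compound 3 (0.13 log units; within the scatter).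

Compound 4 `Cc1cc(C#N)c(S(C)(=O)=O)cc1C(=O)N=C(N)N` is not yet measured. It arises from compound 3 by cyano in place of ethoxy on an aromatic carbon. For the measured compounds named here, no measured step involves a cyano group, so the two steps that bear on the change are those ending at compound 3: from compound 1 a modest rise, a 3.2-fold higher number from compound 1 to compound 3 (0.51 log units; beyond the scatter), and from compound 2 a change within the scatter, a 1.4-fold higher number from compound 2 to compound 3 (0.13 log units; within the scatter). As far as these compounds go, exchanging the group at this position has so far moved this assay only by modest amounts, and the direction for a cyano group is unknown. Compound 4 is therefore expected to show a modest step, a 1.6-fold higher number from compound 3 to compound 4 (0.20 log units; within the scatter), with the estimate 30 nM and a range from 10 nM to 100 nM.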

Compound 4, half-maximal inhibitory concentration: 70 nM
Estimate against measurement, compound 4: 2.3-fold (0.37 log units) below; the measured number falls inside the stated range.
By their numbers in this assay, from the lowest: compound 1; then compounds 2 and 3 (each within the scatter of the next); then compound 4.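

In this assay compound 4 is the weakest of the four, with every step to it beyond the scatter: two are modest (a 3.7-fold higher number from compound 3 to compound 4 (0.57 log units; beyond the scatter) and a 5.0-fold higher number from compound 2 to compound 4 (0.70 log units; beyond the scatter)), and one is large (a 12-fold higher number from compound 1 to compound 4 (1.07 log units; beyond the scatter)). For the compounds shown here, that large step is the first seen at this position, where the exchanges among ethylsulfanyl, phenylsulfanyl and ethoxy had stayed modest or within the scatter. The direction left unknown for cyano is now settled for these compounds: all three groups joined through sulfur or oxygen give lower numbers than cyano, and none of the four goes against this.

Nothing measured here bears on the reason for this rise. As far as these compounds go, whether an amine, a carboxylic acid or a longer alkoxy chain at this position would give a number nearer that of compound 1 or that of compound 4 stays open.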